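The source may hold more compounds than are shown below. What is called first, only, known or untested is meant among the compounds shown, and "the series" means these compounds.

Compound 1 `C/C(=C\COC(=O)NC(C)(C)C)C1=CC(=O)C(C)(C)O1` and compound 2 `C/C(=C\COC(=O)NCc1ccccc1)C1=CC(=O)C(C)(C)O1` share a core and differ only in the group carried on an amide-type nitrogen. In a functional assay on MOLT-4F cells (Homo sapiens) for inhibition (a higher number here means a weaker inhibitor, a lower number a stronger inhibitor), compound 1 gives 6.1 ug/mL, and compound 2 gives 6 ug/mL, so the two numbers lie within the scatter of each other, and compound 1 has no neighbour among the measured compounds that is separated from it by more than the scatter.

Compound 3 `C=CCNC(=O)OC/C=C(\C)C1=CC(=O)C(C)(C)O1` is not yet measured. It differs from compound 1 in one place: allyl in place of tert-butyl on an amide-type nitrogen.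

Among the compounds with values here, the one measured step that bears on this change is the exchange of the same tert-butyl group for benzyl, a 1.0-fold lower number from compound 1 to compound 2 (0.01 log units; within the scatter), which left this assay unchanged. Since a benzyl group and a tert-butyl group on that nitrogen gave the same result, an allyl group there is expected to do likewise, with no step beyond the scatter expected: a 1.0-fold lower number from compound 1 to compound 3 (0.01 log units; within the scatter).

The estimate for compound 3 in this assay is therefore 6 ug/mL, expected to fall between 3 ug/mL and 12 ug/mL.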

Compound 3, half-maximal inhibitory concentration: 7.7 ug/mL
Compound 3: the middle estimate sits 1.3-fold (0.11 log units) below what was measured; measured number inside the range.
By their numbers in this assay, from the lowest: compounds 2, 1 and 3 (each within the scatter of the next).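

In this assay the allyl group becomes a third group on the amide-type nitrogen, with a 1.3-fold higher number from compound 1 to compound 3 (0.10 log units; within the scatter) and a 1.3-fold higher number from compound 2 to compound 3 (0.11 log units; within the scatter) so that all three compounds lie within the scatter of one another. Compound 3 extends the earlier finding to a group with no ring that carries a double bond outside aromatic rings and has fewer heavy atoms than tert-butyl, so the tert-butyl, benzyl and allyl groups on this nitrogen cannot be told apart in this read-out. No measurement at hand accounts for this sameness.

On these data alone, the three groups are all hydrocarbon, so it remains open whether a group of another kind on the same nitrogen, such as a chain ending in an amine or a carboxylic acid, or a much longer alkyl chain, would stay within the scatter as well. All three compounds also share one core and keep the hydrogen on the nitrogen, so the compounds shown say nothing about a methyl group in place of that hydrogen or about any change to the core itself.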